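Acetyl to Fluoro: Expecting the Activity of Compound 4

The source may hold more compounds than are shown below. What is called first, only, known or untested is meant among the compounds shown, and "the series" means these compounds.

Compound 1 `CC(=O)c1cccc(NC(=O)N[C@H](C)c2ccccc2)c1` and compound 2 `CC(=O)c1ccc(NC(=O)N[C@H](C)c2ccccc2)cc1` are built from the same atoms joined differently; the difference between the two cores is not broken down here. In an ADME assay on the whole organism with Oryza sativa as the target, tested at 0.1 uM (a lower number here means a stronger effect, a higher number a weaker effect of the compound at the concentration tested), compound 1 gives 98%, and compound 2 gives 96%. Compound 3 `C[C@@H](NC(=O)Nc1cccc(F)c1)c1ccccc1` arises from compound 1 by fluoro in place of acetyl on an aromatic carbon, the place being meta to a large group, and in this assay compound 3 gives 99%. That change made a number 1 percentage points higher from compound 1 to compound 3 (within the scatter). Compound 4 `C[C@@H](NC(=O)Nc1ccc(F)cc1)c1ccccc1` has not yet been measured; it arises from compound 2 by fluoro in place of acetyl on an aromatic carbon, the same kind of change, though here the place is para to a large group rather than meta. Because a number 1 percentage points higher from compound 1 to compound 3 (within the scatter) stayed within the scatter, the expected step is a number 1 percentage points higher from compound 2 to compound 4 (within the scatter). In this assay compound 4 is therefore estimated at 97%, likely between 90% and 100%.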

Compound 4, a percentage reported as activity, at one concentration (the size of the read-out at that concentration, not a potency): 98%
Beside the measured number, compound 4's estimate is 1 percentage points below it, and the stated range covers the measured number.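

In this assay fluoro in place of acetyl gives a number 2 percentage points higher from compound 2 to compound 4 (within the scatter) and so does on this core what it did on the core of compound 1, as the two steps agree: the same change on two cores in this assay, a number 1 percentage points higher (within the scatter) from compound 1 to compound 3 and a number 2 percentage points higher (within the scatter) from compound 2 to compound 4, 1 percentage points apart, within the scatter of two such steps. Among the compounds shown here, both steps lie within the scatter, so the agreement shows only that this change leaves no readable mark on either core at this one concentration. It does not show that the change has a real effect of a fixed size that carries from core to core, nor that it would stay as quiet on a core with a stronger effect.

The compounds shown leave open what other groups on that aromatic carbon would do, such as an amine or a carboxylic acid, and whether any of them would move the number beyond the scatter.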